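Adding a Second Ring Methyl to Compound 3

This account rests on a few compounds, and the source may have more. Where it says the series, first, only, none or still open, it means among the compounds named here.

Values measured in a functional assay on MCF7 cells (Homo sapiens) for antiproliferative activity, read by sulforhodamine B assay, with a stated time of 48 h (a higher number here means a weaker inhibitor, a lower number a stronger inhibitor), for the three compounds so far:

- Compound 1 (`Cc1ccccc1OS(=O)(=O)c1ccc(N2CCN(C)C2=O)cc1`): 5600 nM
- Compound 2 (`CCN1CCN(c2ccc(S(=O)(=O)Oc3cccc(I)c3)cc2)C1=O`): 1900 nM
- Compound 3 (`CCCN1CCN(c2ccc(S(=O)(=O)Oc3ccccc3C)cc2)C1=O`): > 100000 nM (a limit)

Compound 3 stands at the limit of > 100000 nM in this assay, at which 1 of the 3 values shown sits, and that is a limit, not a number. Going from 2-methylphenyl to 2,4-dimethylphenyl gives compound 4 (`CCCN1CCN(c2ccc(S(=O)(=O)Oc3ccc(C)cc3C)cc2)C1=O`) and the change reads methyl in place of hydrogen on an aromatic carbon in full. It is methyl in place of hydrogen on an aromatic carbon. Among the compounds with values here, no measured step touches this place. Within the data shown here, the only measured step is an at least 17-fold higher number from compound 1 to compound 3 (1.25 log units; beyond the scatter) and it is large, but it lies on a saturated chain, not on the aromatic ring. It shows that one small change can move this assay a long way, and it says nothing about direction here. A reading at the same limit seems about as likely as a number, and any number would have to be a lower one. The expected move is an at least 2.5-fold lower number from compound 3 to compound 4 (0.39 log units; beyond the scatter) and it is only a rough estimate. Compound 4 is estimated at 40000 nM with an expected range from 5000 nM to 100000 nM in this measurement.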

Compound 4, half-maximal inhibitory concentration: 1500 nM
Estimate against measurement, compound 4: 27-fold (1.43 log units) above, outside the stated range (below it).
By their numbers in this assay, from the lowest: compounds 4 and 2 (each within the scatter of the next); then compound 1. At a limit, above all of these: compound 3.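

Methyl in place of hydrogen on an aromatic carbon, para to a large group, gives an at least 66-fold lower number from compound 3 to compound 4 (1.82 log units; beyond the scatter) in this assay. Within the data shown here, this is the first measured change on the aromatic ring, and it shows that this position matters: a single added carbon here is a large step, and it runs in the opposite direction to the earlier chain step, an at least 17-fold higher number from compound 1 to compound 3 (1.25 log units; beyond the scatter). The reading for compound 3 is a limit and not a number, so the step has only a lower bound: the limit of > 100000 nM in this assay, at which 1 of the 4 values shown sits.

As far as these compounds go, whether a chlorine atom, a methoxy group or an ethyl chain at this position would move the number as far remains open. From the compounds shown here alone, it is also open whether the same methyl would have a comparable effect in compound 1.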